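The source may hold more compounds than are shown below. What is called first, only, known or untested is meant among the compounds shown, and "the series" means these compounds.

Measured so far:
Compound 1, `O=[N+]([O-])c1cccc(COCNc2n[n+]([O-])c3ccccc3[n+]2[O-])c1`: 520 nM
Compound 2, `[O-][n+]1nc(NCOCc2ccccc2)[n+]([O-])c2ccccc21`: 4790 nM

Within the data shown here, compound 2 stands at the highest of the two numbers recorded in a functional assay on SMMC-7721 cells (Homo sapiens) for cytotoxicity, read by MTT assay, with a stated time of 72 h (a higher number here means a weaker inhibitor, a lower number a stronger inhibitor), the only neighbour being compound 1, which lies below it by a 9.2-fold higher number from compound 1 to compound 2 (0.96 log units; beyond the scatter) read in reverse. Compound 3, `[O-][n+]1nc(NCOCc2ccc(C(F)(F)F)cc2)[n+]([O-])c2ccccc21`, is not yet measured. It differs from compound 2 in one place: trifluoromethyl in place of hydrogen on an aromatic carbon. Among the measured compounds shown here, the single measured step that speaks to this change is the one from compound 1 to compound 2, where a group on that same six-membered aromatic ring of carbon only was removed and the number rose by a 9.2-fold higher number from compound 1 to compound 2 (0.96 log units; beyond the scatter). Putting a group back onto that ring, here a trifluoromethyl, might therefore be expected to move the number down again, though the group and its place on the ring are not the same as in compound 1, so the size is uncertain. For compound 3 a step of a 3.2-fold lower number from compound 2 to compound 3 (0.50 log units; beyond the scatter) in this assay is expected. The estimate for compound 3 is 1500 nM, with a range from 400 nM to 5000 nM.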

Compound 3, half-maximal inhibitory concentration: 780 nM
The estimate for compound 3 lay 1.9-fold (0.28 log units) above the measured number; measured number inside the range.
By their numbers in this assay, from the lowest: compounds 1 and 3 (each within the scatter of the next); then compound 2.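

With a 6.1-fold lower number from compound 2 to compound 3 (0.79 log units; beyond the scatter) in this assay, the result shows that the number can fall by more than the scatter when a trifluoromethyl stands on the six-membered aromatic ring of carbon only, para to a large group, with no nitro present. Among these compounds, until now, the only sign that a group on this ring matters was the nitro of compound 1, seen in a 9.2-fold higher number from compound 1 to compound 2 (0.96 log units; beyond the scatter) and read in reverse. Compound 2, with only hydrogen in these places, now has the highest number of the three, so the lower number is no longer tied to a single group, although no evidence here says what lies behind the change.

As far as these compounds go, it remains open whether groups of other kinds on this ring, such as an amine, a carboxylic acid or a methoxy group, would also bring the number down from that of compound 2. From the compounds shown here alone, it is also open whether trifluoromethyl would give a similar step at another place on the ring, and whether the chain joining this ring to the shared core can be changed without losing the effect.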